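A bulkier alkyl group on the amine of compound 2

A few compounds are considered here, and "the series" means these few. Any claim that something is new, unique, unknown or untested is made for them only; others in the source may bear on it.

Measured so far:
- compound 1 `Cc1ncc(CO)c2c(Nc3ccccc3)c(NCc3ccccc3)oc12` gives 1680 nM in a functional assay on HEK293 cells for agonist activity at Toll-like receptor 8 (Homo sapiens), read by reporter gene assay; a lower number here means that less compound is needed, a higher number that more compound is needed for the effect
- compound 2 `CCCC(C)Nc1oc2c(C)ncc(CO)c2c1Nc1ccccn1` gives 9010 nM in this assay

Of these two, compound 2 carries the higher number, and compound 1 sits well below it, beyond the usual scatter. Compound 3 `Cc1ncc(CO)c2c(Nc3ccccn3)c(NC(C)(C)CC(C)(C)C)oc12` differs from compound 2 in one place: 1,1,3,3-tetramethylbutyl in place of 1-methylbutyl on a nitrogen on an aromatic ring. Among the compounds with values here, no measured pair shows a change of this kind, so its effect cannot be read from the data. The step expected in this assay is a modest one, a 1.5-fold lower number from compound 2 to compound 3 (0.18 log units; within the scatter), more likely toward a lower number than a higher one. For compound 3 the estimated value is 6000 nM, within a range from 1500 nM to 25000 nM.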

Compound 3, half-maximal effective concentration: "not active" (no number reported)
Nothing numeric was reported for compound 3; the estimate stays without a comparison.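

Within the data shown here, compound 3 is reported as not active in this assay without a number, so no step from compound 2 to compound 3 can be read. The compounds shown leave open how the size of the alkyl group on the amine changes the number. No measurement shown bears on this result.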